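A few compounds are considered here, and "the series" means these few. Any claim that something is new, unique, unknown or untested is made for them only; others in the source may bear on it.

Compound 1 `Cc1cc(Nc2ccc(C(=O)/C=C/c3ccc4ccccc4c3)cc2)n2nc(SCc3ccc(Cl)cc3)nc2n1`: 570 nM
Compound 2 `Cc1ccc(CSc2nc3nc(C)cc(Nc4ccc(C(=O)/C=C/c5ccc6ccccc6c5)cc4)n3n2)cc1`: 880 nM
Compound 3 `Cc1cc(Nc2ccc(C(=O)/C=C/c3ccc4ccccc4c3)cc2)n2nc(SCc3ccccc3)nc2n1`: 300 nM

All three compounds were measured in a functional assay on SW-620 cells (Homo sapiens) for cytotoxicity, read by MTT assay, with stated times of 4 h and 72 h, tested at 5 uM; a lower number here means a stronger inhibitor, a higher number a weaker inhibitor. They share one core and differ only in the group sitting on an aromatic carbon of the benzyl part: chloro in compound 1, methyl in compound 2, and hydrogen in compound 3. Compound 2 gives the highest of the three numbers. Its nearest neighbour is compound 1, and the step of a 1.5-fold higher number from compound 1 to compound 2 (0.19 log units; within the scatter) is within the scatter, so these two cannot be told apart. The step of a 1.9-fold lower number from compound 1 to compound 3 (0.28 log units; within the scatter) is also within the scatter. Among the measured compounds shown here, only the step of a 2.9-fold lower number from compound 2 to compound 3 (0.47 log units; beyond the scatter) is beyond the scatter, a modest one.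

Compound 4 `Cc1cc(Nc2ccc(C(=O)/C=C/c3ccc4ccccc4c3)cc2)n2nc(SCc3ccc(Br)cc3)nc2n1` has not yet been measured. It differs from compound 2 by bromo in place of methyl on an aromatic carbon. For the measured compounds named here, the steps that bear on this change are a 1.5-fold higher number from compound 1 to compound 2 (0.19 log units; within the scatter), which compares chloro with methyl, and a 2.9-fold lower number from compound 2 to compound 3 (0.47 log units; beyond the scatter), which compares methyl with hydrogen. Bromo is a halogen like chloro, so compound 4 is expected to land close to compound 1 rather than compound 3. For compound 4 the expected step is a 1.6-fold lower number from compound 2 to compound 4 (0.20 log units; within the scatter), which stays within the scatter. Compound 4 is therefore estimated at 550 nM, with a range from 280 nM to 1100 nM.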

Compound 4, half-maximal inhibitory concentration: 370 nM
Compound 4: middle estimate off by 1.5-fold (0.17 log units), on the high side, within the range that was stated.
By their numbers in this assay, from the lowest: compounds 3, 4, 1 and 2 (each within the scatter of the next, the first and the last beyond it).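

Moving from 4-methylbenzyl to 4-bromobenzyl in this assay gives the step of a 2.4-fold lower number from compound 2 to compound 4 (0.38 log units; beyond the scatter) as a modest change, so compound 2 now stands apart from two neighbours instead of one. Bromo cannot be told from hydrogen, as the step of a 1.2-fold higher number from compound 3 to compound 4 (0.09 log units; within the scatter) shows, nor from chloro, as the step of a 1.5-fold lower number from compound 1 to compound 4 (0.19 log units; within the scatter) shows, so these three compounds read as one cluster. Methyl therefore separates from hydrogen and bromo, but compound 1 goes against a clean split, since the step of a 1.5-fold higher number from compound 1 to compound 2 (0.19 log units; within the scatter) leaves chloro and methyl indistinguishable even though chloro and bromo also cannot be told apart.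

The compounds shown carry only hydrogen or a single heavy atom at this spot on the benzyl ring, so it remains open whether a methoxy group, an amine or a carboxylic acid placed there would stay with this cluster or move away from it. Nothing given here accounts for why methyl separates from bromo and hydrogen.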